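Penta-1,3-dienoyl in place of indole carbonyl: compound 4

The source may hold more compounds than are shown below. What is called first, only, known or untested is meant among the compounds shown, and "the series" means these compounds.

Compound 3 `CCCCCCCCCCCCCCNC(=O)[C@@H](NC(=O)c1cc2ccccc2[nH]1)[C@@H](C)O` gives the lowest number of the three measured in a functional assay on SW-620 cells (Homo sapiens) for cytotoxicity, read by MTT assay, with a stated time of 48 h (on this read-out higher numbers stand for weaker inhibition and lower numbers for stronger inhibition), 15200 nM. Compound 2 `CCCCCCCCCCCCCCNC(=O)[C@@H](NC(=O)c1nccc2ccccc12)[C@@H](C)O` gives 30400 nM, and the step of a 2.0-fold lower number from compound 2 to compound 3 (0.30 log units; within the scatter) stays within the scatter. Compound 1 `C/C=C/C=C/C(=O)N[C@H](C(=O)NCCCCCCCC)[C@@H](C)O` gives 200000 nM, a gap from compound 3 that lies beyond the scatter. Compound 4 `C/C=C/C=C/C(=O)N[C@H](C(=O)NCCCCCCCCCCCCCC)[C@@H](C)O` differs from compound 3 by penta-1,3-dien-1-yl in place of 1H-indol-2-yl on a carbonyl carbon. For the measured compounds named here, no measured step covers this change directly; the single step available, a 2.0-fold lower number from compound 2 to compound 3 (0.30 log units; within the scatter), exchanges one aromatic acyl group for another and is within the scatter. Compound 1 carries the same penta-1,3-dien-1-yl carbonyl on a shorter chain and gives 200000 nM. Compound 4 is therefore expected to give a higher number, a step of a 3.9-fold higher number from compound 3 to compound 4 (0.60 log units; beyond the scatter). The estimate for compound 4 is 60000 nM, range 20000 nM to 200000 nM.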

Compound 4, half-maximal inhibitory concentration: 200000 nM
Compound 4: the middle estimate sits 3.3-fold (0.52 log units) below what was measured; the range from low to high includes it.
By their numbers in this assay, from the lowest: compounds 3 and 2 (each within the scatter of the next); then compounds 1 and 4 (each within the scatter of the next).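

On the carbonyl carbon, whose other neighbour is the amide-type nitrogen, penta-1,3-dien-1-yl in place of 1H-indol-2-yl gives a 13-fold higher number from compound 3 to compound 4 (1.12 log units; beyond the scatter) in this assay and in place of isoquinolin-1-yl gives a 6.6-fold higher number from compound 2 to compound 4 (0.82 log units; beyond the scatter) on the same chain, so the acyl group at this position now has a measured effect. With penta-1,3-dien-1-yl kept, hexyl in place of hydrogen on the saturated chain carbon, eight bonds along the chain from an amide-type nitrogen, gives no change at the digits printed from compound 1 to compound 4 (within the scatter) and thus no readable chain effect. No available evidence accounts for these differences.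

Still open, on these data alone, is whether an aromatic acyl group changes the number on the shorter chain of compound 1. Also open, as far as these compounds go, is how a longer chain, or an amine on the acyl group, would read.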